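The source may report more compounds than this note shows. Statements on the series, on what has been measured and on what is new or still open speak of the compounds shown alone.

Working notes on the series. Compound 1 `CC(C)(O)c1cn(-c2ccc(-c3ccc(CO)c(S(C)(=O)=O)c3)cc2)c(C(C)(C)c2ccccc2Cl)n1` and compound 2 `CC(C)(O)c1cn(-c2ccc(-c3cc(F)c(CO)c(S(C)(=O)=O)c3)cc2)c(C(C)(C)c2cccc(F)c2Cl)n1` share one core and have both been run in an ADME assay on isolated protein for binding affinity to Alpha-1-acid glycoprotein 1 (Homo sapiens), using equilibrium dialysis, with a stated time of 4 h, tested at 1 uM. In this assay compound 1 gives 90.2%, and compound 2 gives 87.6%. Among the measured compounds shown here, the two values lie within the scatter of each other, so compound 2 cannot be set apart from compound 1 on this read-out; only two compounds have been measured, and no single-point step between them is available.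

Compound 3 `CC(C)(O)c1cn(-c2ccc(-c3cc(F)c(CO)c(S(C)(=O)=O)c3)cc2)c(C(C)(C)c2ccccc2Cl)n1` has not yet been measured in this assay. Relative to compound 2 it carries the change (hydrogen in place of fluoro on an aromatic carbon), that is, hydrogen in place of fluoro on an aromatic carbon, ortho to a chloro group and meta to a large group.

For the measured compounds named here, with no measured step of this kind to rest on, the step from compound 2 to compound 3 in this assay is expected to be small, at a 1.1-fold lower unbound fraction from compound 2 to compound 3 (0.03 log units; within the scatter), not beyond the scatter. For compound 3 the expected value in this assay is 88.5%, with a range of 82% to 93%.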

Compound 3, plasma protein binding: 86.6%
The estimate for compound 3 lay 1.2-fold (0.07 log units) (unbound fraction) below the measured number; measured number inside the range.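

In this assay the change from 2-chlorophenyl to 2-chloro-3-fluorophenyl now has a measured step (a 1.1-fold higher unbound fraction from compound 2 to compound 3 (0.03 log units; within the scatter)), which shows that this fluoro, ortho to a chloro group and meta to a large group, can give way to hydrogen without a shift beyond the scatter. The second single-place pair shows the same for fluoro in place of hydrogen on an aromatic carbon at another place (a 1.4-fold higher unbound fraction from compound 1 to compound 3 (0.14 log units; within the scatter)), so neither exchange separates the compounds on this read-out. No measurement at hand bears on the origin of either step.

The compounds shown carry only fluoro or hydrogen at these carbons, so the effect of a larger group there, such as methoxy or a nitrile, remains open. Also open, from the compounds shown here alone, is what an amine or a carboxylic acid on the shared core would do in this assay.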